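Heteroaryl Swap on the Amide Carbonyl: Compound 4

A few compounds are considered here, and "the series" means these few. Any claim that something is new, unique, unknown or untested is made for them only; others in the source may bear on it.

Measured so far in an ADME assay on microsomes from liver (Homo sapiens) for metabolic stability, read by LC-MS, with a stated time of 30 min, tested at 1 uM; on this read-out lower numbers stand for a less stable compound and higher numbers for a more stable compound:
compound 1 `O=C(NCc1ccc(S(=O)(=O)c2ccccc2)cc1)c1ccc2nncn2c1` gives 96%
compound 2 `O=C(NCc1ccc(S(=O)(=O)c2ccccc2)cc1)c1cn2ccnc2cn1` gives 87%
compound 3 `O=C(NCc1ccc(S(=O)(=O)c2ccccc2)cc1)c1nc2ccncc2s1` gives 68%

Compound 3 stands lowest of the three numbers: a number 19 percentage points lower from compound 2 to compound 3 (beyond the scatter) is the nearer gap, and a number 28 percentage points lower from compound 1 to compound 3 (beyond the scatter) the wider one, both beyond the scatter. Compound 4 `O=C(NCc1ccc(S(=O)(=O)c2ccccc2)cc1)c1c[nH]c2ccncc12` differs from compound 3 at the carbonyl carbon: a group of 9 heavy atoms (7 carbon, 2 nitrogen; one five-membered aromatic ring with 1 hetero atom, one six-membered aromatic ring with 1 hetero atom) in place of a group of 9 heavy atoms (6 carbon, 2 nitrogen, 1 sulfur; one five-membered aromatic ring with 2 hetero atoms, one six-membered aromatic ring with 1 hetero atom), on a carbonyl carbon. The three earlier steps all exchanged the bicyclic group on this same carbonyl; a number 9 percentage points lower from compound 1 to compound 2 (within the scatter) stayed within the scatter, while the two steps into compound 3 were modest. A modest step in either direction is therefore plausible for compound 4 in this assay, with none beyond the scatter the likeliest outcome. Compound 4 is estimated at 70%, within 45% to 92%, which is expected to mean a number 2 percentage points higher from compound 3 to compound 4 (within the scatter).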

Compound 4, percent of the compound remaining: > 99%
Compound 4 was reported as a limit (the forecaster's own chance of this, stated with the estimate: 3%); middle value at least 29 percentage points from the limit.
By their numbers in this assay, from the lowest: compound 3; then compounds 2 and 1 (each within the scatter of the next). At a limit, above all of these: compound 4.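

In this assay compound 4 gives > 99%, which is a limit of the assay and not a number: the limit of > 99% in this assay, at which 1 of the 4 values shown sits. The group on this carbonyl carbon can therefore move the read-out upward as well as downward, with a number at least 31 percentage points higher from compound 3 to compound 4 (beyond the scatter) and a number at least 12 percentage points higher from compound 2 to compound 4 (beyond the scatter). Against compound 1 the result gives only a number at least 3 percentage points higher from compound 1 to compound 4 (that floor lies within the scatter), so no order can be read between these two.

The compounds shown leave open how the enters-group would read in this assay with a methyl, a fluorine or an amine added to it. They also leave open whether these steps would hold on a different core.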